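Chloro on the benzyl arm of the shared core

The source may hold more compounds than are shown below. What is called first, only, known or untested is meant among the compounds shown, and "the series" means these compounds.

Of the compounds shown here, three have been measured in a functional assay on HepG2 cells (Homo sapiens) for cytotoxicity, read by MTT assay, with a stated time of 48 h; a lower number here means a stronger inhibitor, a higher number a weaker inhibitor. Compound 1 `O=C(CSc1nc2ccc(NC(=O)c3ccc(Cl)cc3)cc2s1)NCc1ccc(Cl)cc1` gives 17800 nM; compound 2 `O=C(CSc1nc2ccc(NC(=O)c3ccccc3)cc2s1)NCc1ccc(Cl)cc1` gives 30100 nM; compound 3 `COc1ccccc1C(=O)Nc1ccc2nc(SCC(=O)NCc3ccccc3)sc2c1` gives 8000 nM, the lowest of the three numbers, with compound 1 nearest and compound 2 furthest. Compound 4 `COc1ccccc1C(=O)Nc1ccc2nc(SCC(=O)NCc3ccc(Cl)cc3)sc2c1` differs from compound 3 by chloro in place of hydrogen on an aromatic carbon, on an aromatic carbon para to a large group. For the measured compounds named here, one measured step bears on this change, run in the opposite direction: a 1.7-fold higher number from compound 1 to compound 2 (0.23 log units; within the scatter), a chloro-to-hydrogen swap on the same benzyl ring. Its reverse suggests only a step within the scatter, toward a lower number if anything. Compound 4 is therefore expected at 5500 nM, with a range of 2200 nM to 14000 nM. This corresponds to an estimated step of a 1.5-fold lower number from compound 3 to compound 4 (0.16 log units; within the scatter).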

Compound 4, half-maximal inhibitory concentration: 600 nM
Compound 4: middle estimate off by 9.2-fold (0.96 log units), on the high side; the whole stated range lies above it.
By their numbers in this assay, from the lowest: compound 4; then compound 3; then compounds 1 and 2 (each within the scatter of the next).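

With the 2-methoxyphenyl amide in place, chloro on the benzyl ring is a large step, not a small one: a 13-fold lower number from compound 3 to compound 4 (1.12 log units; beyond the scatter). With the 4-chlorobenzyl arm held, the amide side also weighs heavily: methoxy in place of hydrogen gives a 50-fold lower number from compound 2 to compound 4 (1.70 log units; beyond the scatter), and 2-methoxyphenyl in place of 4-chlorophenyl gives a 30-fold lower number from compound 1 to compound 4 (1.47 log units; beyond the scatter). The size of the chloro step therefore depends on the group at the other end of the shared core: the same change on two cores in this assay, a 1.7-fold higher number (0.23 log units; within the scatter) from compound 1 to compound 2 and a 13-fold higher number (1.12 log units; beyond the scatter) from compound 4 to compound 3, 7.9-fold (0.90 log units) apart, beyond the scatter of two such steps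

As far as these compounds go, whether bromo, methyl or an amine on the benzyl ring would match chloro stays open. So does whether this dependence holds for acyl groups beyond the three shown.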